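Methoxy on the Styryl Lactam: Expected Growth Inhibition

This account rests on a few compounds, and the source may have more. Where it says the series, first, only, none or still open, it means among the compounds named here.

Compound 2 `O=C1C=CCC(/C=C/c2ccccc2)N1` is the plainest member of a small set measured in a functional assay on NCI/ADR cells (Homo sapiens) for inhibition, read by sulforhodamine B assay, with a stated time of 48 h; a higher number here means a weaker inhibitor of growth, a lower number a stronger inhibitor of growth. In this assay compound 2 gives 967 uM, the highest of the three numbers recorded. The nearest of the others is compound 1 `COc1ccc(/C=C/C2CC(=O)C=CO2)cc1OC`, which in this assay gives 146 uM; the furthest is compound 3 `O=C1C=CCC(/C=C/c2ccccc2C(F)(F)F)N1`, which in this assay gives 40.6 uM.

Compound 4 `COc1ccc(/C=C/C2CC=CC(=O)N2)cc1` has not yet been measured. It differs from compound 2 in one place: methoxy in place of hydrogen on an aromatic carbon.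

For the measured compounds named here, only one measured step bears directly on this change, since it is the only one that adds a group to the aromatic ring of compound 2: a 24-fold lower number from compound 2 to compound 3 (1.38 log units; beyond the scatter). Compound 1 carries two methoxy groups on its ring, but its core is not the shared core of compounds 2 and 3, so its value offers only loose support for what a methoxy group alone might do.

On that basis the writer expects a step toward a lower number, a 2.4-fold lower number from compound 2 to compound 4 (0.38 log units; beyond the scatter), smaller than the trifluoromethyl step but beyond the scatter. Compound 4 is therefore estimated to give 400 uM in this assay, with a range from 150 uM to 1000 uM.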

Compound 4, concentration for growth inhibition (reported as GI): 842 uM
The estimate for compound 4 lay 2.1-fold (0.32 log units) below the measured number; the range from low to high includes it.
By their numbers in this assay, from the lowest: compound 3; then compound 1; then compounds 4 and 2 (each within the scatter of the next).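

The step of a 1.1-fold lower number from compound 2 to compound 4 (0.06 log units; within the scatter) in this assay shows that methoxy, on an aromatic carbon para to a group of 9 heavy atoms, brings no change that can be told from the scatter. For the compounds shown here, the only earlier step on the ring of compound 2, a 24-fold lower number from compound 2 to compound 3 (1.38 log units; beyond the scatter), lay beyond the scatter, so a group added to this ring does not always move the number: trifluoromethyl in compound 3 did, and methoxy in compound 4 did not. Nothing measured here accounts for the difference between these two steps, and no cause can be given for either of them.

The compounds shown leave open whether trifluoromethyl, placed where methoxy stands in compound 4, would give a step like the one seen for compound 3. They also leave open whether an amine, a carboxylic acid or a chloro group at this same place, or methoxy on another carbon of the ring, would carry the number beyond the scatter.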